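The source may report more compounds than this note shows. Statements on the series, on what has been measured and on what is new or still open speak of the compounds shown alone.

Measured so far: compound 1 `[N-]=[N+]=NC[C@@H]1O[C@H](CO)[C@@H](O)[C@H](O)[C@H]1O` gives 15800000 nM in an assay on isolated protein (Sus scrofa) for inhibition of glycogen phosphorylase, brain form (Homo sapiens); on this read-out higher numbers stand for weaker inhibition and lower numbers for stronger inhibition; compound 2 `NC[C@H]1O[C@H](CO)[C@@H](O)[C@H](O)[C@H]1O` gives 31600000 nM.

Compound 2 and compound 1 lie within the scatter of each other, so both stand at the same very weak level in this assay. Compound 3 `NC[C@@H]1O[C@H](CO)[C@@H](O)[C@H](O)[C@H]1O` is the next compound: the two compounds have the same atoms and bonds and differ only in configuration as drawn: 1 of 5 stereo elements differ; a stereocentre at a saturated ring carbon is drawn R in compound 2 and S in compound 3. Among the measured compounds shown here, no step between measured compounds shows what such a change does, so in this assay only a step within the scatter, in either direction, is expected. Compound 3 is therefore estimated at 20000000 nM, with a range from 6000000 nM to 65000000 nM. That amounts to an expected 1.6-fold lower number from compound 2 to compound 3 (0.20 log units; within the scatter).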

Compound 3, inhibition constant: 15800000 nM
Compound 3: middle estimate off by 1.3-fold (0.10 log units), on the high side; the measured number falls inside the stated range.
By their numbers in this assay, from the lowest: compounds 1, 3 and 2 (each within the scatter of the next).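

In this assay, redrawing this saturated ring carbon from R to S gives a 2.0-fold lower number from compound 2 to compound 3 (0.30 log units; within the scatter), so the configuration here has no effect that can be told from the scatter. The comparison isolates that stereocentre alone: the fact that compounds 2 and 3 differ only in the configuration as drawn. On the chain carbon, amino in place of azido gives no change at the digits printed from compound 1 to compound 3 (within the scatter), so this exchange also leaves the level unmoved.

All three compounds remain at the same very weak level. On these data alone, whether a carboxylic acid or a longer chain at this place would move the number, and whether configuration would then matter, remains open.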